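Cyclohexylamino analogue of the nitro-substituted series in Vero cytotoxicity

The compounds below may be only part of what the source reports. "The series", "measured", "known", "first", "only" and "open" are said of these compounds alone.

Compound 3 `O=c1cc(NCC2CCCCC2)sc2c([N+](=O)[O-])cc(C(F)(F)F)cc12` is the reference point for this note, measured in an ADME assay on Vero cells (Chlorocebus sabaeus) for cytotoxicity, read by MTT assay, with a stated time of 48 h; on this read-out lower numbers stand for stronger inhibition and higher numbers for weaker inhibition. In this assay compound 3 gives > 64 ug/mL, which is a limit of the assay and not a number. Compound 1 `O=c1cc(NCc2ccc3c(c2)OCCO3)sc2c([N+](=O)[O-])cc(C(F)(F)F)cc12` in this assay gives > 64 ug/mL, likewise a limit. Compound 2 `O=c1cc(Nc2ccccc2)sc2c([N+](=O)[O-])cc(C(F)(F)F)cc12` in this assay gives > 64 ug/mL, also a limit. The two measured steps that end at compound 3, a step that the two limits leave unreadable from compound 1 to compound 3 and a step that the two limits leave unreadable from compound 2 to compound 3, therefore carry no readable size; the only firm statement is the limit of > 64 ug/mL in this assay, at which 3 of the 3 values shown sit.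

Compound 4 `O=c1cc(NC2CCCCC2)sc2c([N+](=O)[O-])cc(C(F)(F)F)cc12` differs from compound 3 in one place: cyclohexyl in place of cyclohexylmethyl on a nitrogen on an aromatic ring. Neither of the measured steps bears on this change in a readable way, since both start and end at the same limit. No step in this assay has yet shown a size beyond the scatter, and no change among compounds 1, 2 and 3 has moved a value off the limit. The expectation is therefore that compound 4 will again sit at the limit, with a step that the limit leaves unreadable from compound 3 to compound 4 that is not expected to exceed the scatter. Compound 4 in this assay is estimated at 90 ug/mL, with a range of 40 ug/mL to 200 ug/mL.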

Compound 4, half-maximal inhibitory concentration: > 64 ug/mL
Compound 4 ended at the assay's limit (the forecaster's own chance of this, stated with the estimate: 85%); the middle value lies beyond the limit too.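

In this assay compound 4 gives > 64 ug/mL, which is a limit of the assay and not a number. The steps from compound 2 and from compound 3 to compound 4 therefore cannot be read: the limit of > 64 ug/mL in this assay, at which 4 of the 4 values shown sit.

The compounds shown leave open where a numerical value for any of them lies, and whether the group on the nitrogen changes it at all.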